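The source may report more compounds than this note shows. Statements on the series, on what has been measured and on what is new or still open speak of the compounds shown alone.

Measured so far in a functional assay on MCF7 cells (Homo sapiens) for cytotoxicity, read by MTT assay, with a stated time of 24 h, tested at 1.6 ug/mL; on this read-out higher numbers stand for a stronger effect at the one concentration tested and lower numbers for a weaker effect:
compound 1 `Cn1c(-c2ccc(NC(=O)CSc3nc4cc(Cl)ccc4o3)cc2)nc(-c2ccccc2)c1-c1ccccc1` gives 2.5%
compound 2 `Cc1ccc2oc(SCC(=O)Nc3ccc(-c4nc(-c5ccccc5)c(-c5ccccc5)n4C)cc3)nc2c1` gives 1.9%

Compound 2 holds the lowest of the two numbers in this assay; its nearest neighbour is compound 1, and the step of a number 0.6 percentage points lower from compound 1 to compound 2 (within the scatter) lies within the scatter, so the two values are read as the same.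

Compound 3 `Cn1c(-c2ccc(NC(=O)CSc3nc4ccccc4s3)cc2)nc(-c2ccccc2)c1-c1ccccc1` is not yet measured. Against compound 2 the change is 1,3-benzothiazol-2-yl in place of 5-methyl-1,3-benzoxazol-2-yl on a sulfur. Within the data shown here, the one measured step, a number 0.6 percentage points lower from compound 1 to compound 2 (within the scatter), exchanges a single substituent on an aromatic carbon of the 5-methyl-1,3-benzoxazol-2-yl group and left the read-out inside the scatter; it bears on the present change only in showing that a small edit of that group did not move the number. Among the measured compounds shown here, no measured step replaces the group itself by 1,3-benzothiazol-2-yl, so the present change is not covered directly. Both measured values sit near the bottom of the scale, leaving little room for a downward step. Accordingly no step beyond the scatter is expected in this assay, a number 1.1 percentage points higher from compound 2 to compound 3 (within the scatter). Compound 3 is therefore estimated at 3%, with a range from 0% to 12%.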

Compound 3, a percentage reported as activity, at one concentration (the size of the read-out at that concentration, not a potency): 2.1%
The estimate for compound 3 lay 0.9 percentage points above the measured number; the range from low to high includes it.
By their numbers in this assay, from the lowest: compounds 2, 3 and 1 (each within the scatter of the next).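

In this assay, exchanging the whole group on the sulfur, not just one substituent on it, gives a number 0.2 percentage points higher from compound 2 to compound 3 (within the scatter), and the same kind of exchange starting from the chloro analogue gives a number 0.4 percentage points lower from compound 1 to compound 3 (within the scatter). At this place, on a sulfur whose other neighbour is a saturated chain carbon, 1,3-benzothiazol-2-yl therefore reads the same as 5-methyl-1,3-benzoxazol-2-yl and the chloro analogue, so the insensitivity seen earlier for a substituent edit now also holds for a change of the group itself, in which sulfur takes the place of oxygen and the methyl is lost. Nothing available explains why these three compounds read alike.

As far as these compounds go, with all three values near the bottom of the scale, it remains open whether a different kind of group at this place, such as a piperidine amine or a carboxylic acid, or a longer chain in place of the sulfanylmethyl link, would move the read-out at all. The single tested concentration also leaves open whether compound 1, compound 2 and compound 3 would separate at any other concentration.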